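A few compounds are considered here, and "the series" means these few. Any claim that something is new, unique, unknown or untested is made for them only; others in the source may bear on it.

In a functional assay on KYSE-450 cells (Homo sapiens) for inhibition, read by CCK-8 assay, with a stated time of 48 h (on this read-out lower numbers stand for stronger inhibition and higher numbers for weaker inhibition), compound 1 `COc1ccc(CN(C(=O)CSC(=S)N2CCN(C(=O)OC(C)(C)C)CC2)c2cc(OC)c(OC)c(OC)c2)cc1` gives 250 nM and compound 2 `CCN1CCN(CC(=O)N(Cc2ccc(OC)cc2)c2cc(OC)c(OC)c(OC)c2)CC1` gives 16100 nM. Compound 3 `COc1cc(N(Cc2ccc(C)cc2)C(=O)CSC(=S)N2CCN(C(=O)OC(C)(C)C)CC2)cc(OC)c1OC` gives only a limit, > 20000 nM, so its standing in the series has no exact number. Compound 4 `COc1ccc(CN(C(=O)CSC(=S)N2CCN(C(=O)OC(C)(C)C)CC2)c2cc(OC)c(OC)c(OC)c2)cc1Br` differs from compound 3 as follows: 3-bromo-4-methoxyphenyl in place of 4-methylphenyl on a saturated chain carbon bound to an amide-type nitrogen. In words, 3-bromo-4-methoxyphenyl replaces 4-methylphenyl. Among the compounds with values here, one measured step bears on this: methyl in place of methoxy on an aromatic carbon, large and beyond the scatter. Within the data shown here, compound 4 brings the methoxy back and also carries bromine, whose contribution no measured step shows. Because of an at least 80-fold higher number from compound 1 to compound 3 (1.90 log units; beyond the scatter), a large move toward lower numbers is expected in this assay. The expected size is an at least 50-fold lower number from compound 3 to compound 4 (1.69 log units; beyond the scatter). For compound 4 the estimate is 400 nM, with an expected range of 60 nM to 4000 nM.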

Compound 4, half-maximal inhibitory concentration: 1850 nM
Compound 4: middle estimate off by 4.6-fold (0.67 log units), on the low side; the range from low to high includes it.
By their numbers in this assay, from the lowest: compound 1; then compound 4; then compound 2. At a limit, above all of these: compound 3.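

In this assay, 3-bromo-4-methoxyphenyl in place of 4-methylphenyl on a saturated chain carbon bound to an amide-type nitrogen recovers much of the inhibition, giving an at least 10-fold lower number from compound 3 to compound 4 (1.03 log units; beyond the scatter). The added bromine is not neutral at this position: bromo in place of hydrogen on an aromatic carbon gives a 7.4-fold higher number from compound 1 to compound 4 (0.87 log units; beyond the scatter). The size of the first step remains open-ended, as one end of it is a limit: the limit of > 20000 nM in this assay, at which 1 of the 4 values shown sits.

Open, as far as these compounds go, is whether fluoro, chloro or an amine at the bromine's place would give a number closer to that of compound 1. Also open, from the compounds shown here alone, is whether bromine on another carbon of this group would give the same result.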